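The source may report more compounds than this note shows. Statements on the series, on what has been measured and on what is new or still open speak of the compounds shown alone.

Two compounds have been measured so far in a functional assay on HCT-116 cells (Homo sapiens) for cytotoxicity, read by scintillation counting and thymidine incorporation, with a stated time of 72 h; on this read-out higher numbers stand for weaker inhibition and lower numbers for stronger inhibition:

Compound 1 `CCOc1cc(C(=CC#N)c2ccc(NC)cc2)ccc1OC` gives 55 nM
Compound 2 `CCOc1cc(C(=CC#N)c2ccc(N(C)C)cc2)ccc1OC` gives 31 nM

Going by the values given here, compound 2 (at 31 nM) stands level with compound 1, the only other compound measured, and the two cannot be told apart. The open question is compound 3 (`CCOc1cc(C(=CC#N)c2ccc(S(C)(=O)=O)cc2)ccc1OC`), which carries methylsulfonyl in place of dimethylamino on an aromatic carbon. Among the compounds with values here, only one measured step bears on this change (a 1.8-fold lower number from compound 1 to compound 2 (0.25 log units; within the scatter)). That step adds a methyl on the nitrogen and stays small. Within the data shown here, it keeps the nitrogen, however, while compound 3 has none, and no measured compound shows what losing it does. The small step is therefore a weak guide. A clearly larger step is expected in this assay, towards a higher number, but this direction is a judgement and not a measured trend. The expected change is wide in its margins (a 16-fold higher number from compound 2 to compound 3 (1.21 log units; beyond the scatter)). The estimated value for compound 3 is 500 nM within an expected range of 60 nM to 4000 nM given so little data.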

Compound 3, half-maximal inhibitory concentration: > 10000 nM
Compound 3: a limit, no number; the forecaster's own chance of this, stated with the estimate: 10%; at least 20-fold (1.30 log units) between middle value and limit.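

In this assay compound 3 gives > 10000 nM, which is a limit of the assay and not a number: the limit of > 10000 nM in this assay, at which 1 of the 3 values shown sits.

Until now, this aromatic carbon, para to a large group, had only carried two nitrogen groups that differ by one methyl, and these could not be told apart. The new result shows that the position is far from indifferent to what sits there: methylsulfonyl in place of dimethylamino gives an at least 320-fold higher number from compound 2 to compound 3 (2.50 log units; beyond the scatter), and methylsulfonyl in place of methylamino gives an at least 180-fold higher number from compound 1 to compound 3 (2.25 log units; beyond the scatter). Going by these compounds alone, both steps lie well beyond the scatter, so in these three compounds, activity in the nanomolar range is seen only with a nitrogen group on this carbon.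

The compounds shown leave open whether the large step comes from losing the nitrogen or from gaining the methylsulfonyl group, as this single swap changes both at once. A plain hydrogen, a methyl or a methoxy group on the same carbon would help to separate these two readings, while an unsubstituted amine or a piperidine would show how much variation the nitrogen itself tolerates.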